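This account rests on a few compounds, and the source may have more. Where it says the series, first, only, none or still open, it means among the compounds named here.

Working notes on the series. Within the data shown here, compound 1 `CC1=CC[C@H](C(C)(C)NC(=S)N/N=C/c2ccccc2O)CC1` gives 10600 nM in a functional assay on U-251 cells (Homo sapiens) for inhibition, read by sulforhodamine B assay, with a stated time of 48 h; on this read-out higher numbers stand for weaker inhibition of growth and lower numbers for stronger inhibition of growth; it is the only compound of the pair with a number. Compound 2 `CC1=CC[C@H](C(C)(C)NC(=S)N/N=C/c2ccccc2[N+](=O)[O-])CC1` reaches only the assay limit of > 100000 nM in this assay. Among the measured compounds shown here, the single measured step, an at least 9.4-fold higher number from compound 1 to compound 2 (0.97 log units; beyond the scatter), is told by the limit of > 100000 nM in this assay, at which 1 of the 2 values shown sits, and so is a lower bound on the change.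

Compound 3 `CC1=CC[C@H](C(C)(C)NC(=S)N/N=C/c2cccs2)CC1` differs from compound 1 by thiophen-2-yl in place of 2-hydroxyphenyl on a carbon with a double bond to nitrogen. For the measured compounds named here, no measured step matches this change. The step from compound 1 to compound 2 bears on it only loosely, since both changes remove the hydroxy donor of the 2-hydroxyphenyl; that step was at least modest and toward weaker inhibition. A step in the same direction, of smaller size, is therefore expected here: a 2.8-fold higher number from compound 1 to compound 3 (0.45 log units; beyond the scatter). Compound 3 is expected to give about 30000 nM in this assay, within roughly 8000 nM to 100000 nM.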

Compound 3, concentration for total growth inhibition: 27400 nM
The estimate for compound 3 lay 1.1-fold (0.04 log units) above the measured number, and the stated range covers the measured number.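

Among these compounds, at this position, the change gives a 2.6-fold higher number from compound 1 to compound 3 (0.41 log units; beyond the scatter) in this assay, the first step here that can be read as a full number and not as a bound. Both compounds without the hydroxy group give higher numbers than compound 1, and neither compound shown goes against this pattern, though thiophen-2-yl still leaves a measurable value. Compound 2 gives > 100000 nM, which is a limit of the assay, so the size of the new step cannot be ranked against that of the step to compound 2: the limit of > 100000 nM in this assay, at which 1 of the 3 values shown sits.

The step to compound 3 changes the ring and removes the hydroxy group together, so the compounds shown do not separate these two changes. As far as these compounds go, what a plain phenyl, a 2-methoxyphenyl or a 2-aminophenyl group would give on the carbon with a double bond to nitrogen stays open.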